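The compounds below may be only part of what the source reports. "The series", "measured", "known", "first", "only" and "open" are said of these compounds alone.

In a functional assay on MDA-MB-231 cells (Homo sapiens) for antiproliferative activity, read by MTT assay, with a stated time of 48 h (a lower number here means a stronger inhibitor, a higher number a weaker inhibitor), compound 1 (`COc1ccc(N(C)c2ccnc(Cl)n2)cc1F`) gives 1280 nM and compound 3 (`COc1ccc(N(C)c2ccnc(Cl)n2)cc1OCCC[Se]C#N`) gives 1490 nM, so the two stand level within the scatter, with a 1.2-fold higher number from compound 1 to compound 3 (0.07 log units; within the scatter) between them. Compound 2 (`COc1ccc(N(C)c2ccnc(Cl)n2)cc1OCCCCCBr`) reads > 10000 nM, which is a limit of the assay. Compound 4 (`COc1ccc(N(C)c2ccnc(Cl)n2)cc1OCCCC[Se]C#N`) departs from compound 3 by a group of 4 heavy atoms (2 carbon, 1 nitrogen, 1 selenium; no ring) in place of a group of 3 heavy atoms (1 carbon, 1 nitrogen, 1 selenium; no ring), on a saturated chain carbon, three bonds along the chain from an oxygen on an aromatic ring in this assay terms of structure alone. Within the data shown here, the nearest measured change, an at least 6.7-fold lower number from compound 2 to compound 3 (0.82 log units; beyond the scatter), sits at that same saturated chain carbon but exchanges a different group, and no measured step tests this change alone. Among the measured compounds shown here, with a 1.2-fold higher number from compound 1 to compound 3 (0.07 log units; within the scatter) as the only other numeric guide, no step beyond the scatter is expected, an estimated 1.0-fold higher number from compound 3 to compound 4 (0.00 log units; within the scatter) here. Compound 4 is expected at 1500 nM, within an estimated range of 500 nM to 5000 nM.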

Compound 4, half-maximal inhibitory concentration: > 10000 nM
Compound 4 gave a limit, no number (the forecaster's own chance of this, stated with the estimate: 8%); middle value at least 6.6-fold (0.82 log units) away from the limit.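

In this assay, the group of 4 heavy atoms in place of the group of 3 heavy atoms, on this saturated chain carbon, gives an at least 6.7-fold higher number from compound 3 to compound 4 (0.82 log units; beyond the scatter), so a small change at this place can decide the result. The earlier level reading of compound 3 with compound 1 does not carry over, with an at least 7.8-fold higher number from compound 1 to compound 4 (0.89 log units; beyond the scatter). Compound 4 reads a limit, as compound 2 does, and the step between them cannot be read: the limit of > 10000 nM in this assay, at which 2 of the 4 values shown sit.

On these data alone, what a shorter or longer chain ending in the same selenium and nitrile unit would give remains open. So does the effect of an amine at the chain end.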